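Aryl swap on the triazole in an inactive series

The compounds below may be only part of what the source reports. "The series", "measured", "known", "first", "only" and "open" are said of these compounds alone.

Compound 3 `N#CC1=C(N)Oc2c(N)cc3nc4ccccc4nc3c2C12C(=O)N(Cc1cnnn1-c1ccc(Cl)cc1)c1ccccc12` was tested in a functional assay on MCF7 cells (Homo sapiens) for antiproliferative activity, read by MTT assay, with a stated time of 48 h; a higher number here means a weaker inhibitor, a lower number a stronger inhibitor; there compound 3 gives > 50000 nM, which is a limit of the assay rather than a number. Compound 1 `N#CC1=C(N)Oc2c(c3nc4ccccc4nc3c3ccccc23)C12C(=O)N(Cc1cnnn1-c1ccccc1Br)c1ccccc12` gives > 50000 nM, likewise a limit. Compound 2 `Cc1ccc(C)c(-n2nncc2CN2C(=O)C3(C(C#N)=C(N)Oc4c3c3nc5ccccc5nc3c3ccccc43)c3ccccc32)c1` gives > 50000 nM, again a limit. The change considered is 3,4-dimethylphenyl in place of 4-chlorophenyl on an aromatic nitrogen, giving compound 4 `Cc1ccc(-n2nncc2CN2C(=O)C3(C(C#N)=C(N)Oc4c(N)cc5nc6ccccc6nc5c43)c3ccccc32)cc1C`. For the measured compounds named here, the only measured step of related kind, a step that the two limits leave unreadable from compound 1 to compound 2, cannot be read because of the limit of > 50000 nM in this assay, at which 3 of the 3 values shown sit. With every value shown sitting at that limit, no direction can be taken from the data, and compound 4 is expected to stay at the limit as well. Compound 4 is therefore estimated at 80000 nM, within 30000 nM to 300000 nM, a step that the limit leaves unreadable from compound 3 to compound 4 expected only as a formality.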

Compound 4, half-maximal inhibitory concentration: > 50000 nM
Compound 4 ended at the assay's limit; the forecaster's own chance of this, stated with the estimate: 85%; the middle value does not contradict the limit.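

No size can be read for the change from compound 3 to compound 4, since both sit at a limit rather than a number: the limit of > 50000 nM in this assay, at which 4 of the 4 values shown sit.

The compounds shown leave open whether any group on that aromatic nitrogen would give a measurable value.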